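Oxime ether variation on the shared core

A few compounds are considered here, and "the series" means these few. Any claim that something is new, unique, unknown or untested is made for them only; others in the source may bear on it.

Measured so far:
compound 1 `CCO/N=C(\C)c1ccccc1NCC1=NCCN1` — in this assay: < 5020 nM
compound 2 `CO/N=C/c1ccccc1NCC1=NCCN1` — in this assay: < 5020 nM

In a functional assay for activation of Alpha-1D adrenergic receptor (Homo sapiens) (a lower number here means that less compound is needed, a higher number that more compound is needed for the effect), compound 1 gives < 5020 nM, which is a limit of the assay and not a number. Compound 2 likewise gives < 5020 nM, again a limit rather than a number. Both shown values thus sit at the same limit (the limit of < 5020 nM in this assay, at which 2 of the 2 values shown sit), so the step that the two limits leave unreadable from compound 1 to compound 2 cannot be read in size or direction.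

Compound 3 `CC/C(=N/OC)c1ccccc1NCC1=NCCN1` differs from compound 2 by a group of 6 heavy atoms (4 carbon, 1 nitrogen, 1 oxygen; no ring) in place of a group of 4 heavy atoms (2 carbon, 1 nitrogen, 1 oxygen; no ring), on an aromatic carbon. Among the measured compounds shown here, the only measured step, from compound 1 to compound 2, concerns this same position but is unreadable, so no measured step gives a usable size for the change at hand. Compound 3 is therefore expected to show a step that the limit leaves unreadable from compound 2 to compound 3, with no direction beyond the scatter claimed. Compound 3 is estimated at 1500 nM, ranging from 300 nM to 5020 nM, and most likely the assay again reports only a limit.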

Compound 3, half-maximal effective concentration: < 5020 nM
Compound 3 gave a limit, no number (the forecaster's own chance of this, stated with the estimate: 65%); the middle value is on the limit's open side.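

In this assay compound 3 gives < 5020 nM, a limit and not a number. Its steps to compound 1 and compound 2 therefore cannot be read: the limit of < 5020 nM in this assay, at which 3 of the 3 values shown sit.

Still open, on these data alone, is what actual values these three compounds have in this assay, and whether changing the oxime ether group alters them at all.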